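The compounds below may be only part of what the source reports. "The series", "measured", "known", "first", "only" and "open" are said of these compounds alone.

Measured compounds in a functional assay on HCT-116 cells (Homo sapiens) for antiproliferative activity, read by MTT assay, with a stated time of 48 h; on this read-out higher numbers stand for weaker inhibition and lower numbers for stronger inhibition:
Compound 1, `CCC(CCO)n1cnc2c(Cl)nc(F)nc21`, gives 18900 nM.
Compound 2, `CCC(CCO)n1cnc2c(Cl)ncnc21`, gives > 50000 nM, which is a limit of the assay rather than a number.
Compound 3, `CCCCCCCC(CCO)n1cnc2c(N)ncnc21`, gives > 50000 nM, likewise a limit of the assay and not a number.

Compound 2 therefore stands at the limit of > 50000 nM in this assay, at which 2 of the 3 values shown sit; its own result in this assay is a limit, so only a floor on its number is known. Among the measured compounds shown here, the one step measured is an at least 2.6-fold higher number from compound 1 to compound 2 (0.42 log units; beyond the scatter); it concerns a substituent on the aromatic ring and does not touch the saturated chain. The change now followed is heptyl in place of hydrogen on a saturated chain carbon, three bonds along the chain from an aromatic nitrogen, giving compound 4, `CCCCCCCCCC(CCO)n1cnc2c(Cl)ncnc21`. For the measured compounds named here, compound 3 also carries a long saturated chain, but it differs from compound 4 in two places, so no step is drawn from it; its result shows only that a long chain combined with an amino group on the core also sits at the limit. Going by the values given here, no measured step bears on the heptyl change, so the step expected in this assay is none beyond the scatter, with compound 4 expected to remain at the limit. The step expected here is a step that the limit leaves unreadable from compound 2 to compound 4. Compound 4 is estimated at 60000 nM, within 30000 nM to 200000 nM.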

Compound 4, half-maximal inhibitory concentration: 890 nM
Compound 4: middle estimate off by 67-fold (1.83 log units), on the high side; the whole stated range lies above it.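

In this assay, the saturated chain carbon three bonds along the chain from an aromatic nitrogen turns out to be a place where a change registers strongly: heptyl in place of hydrogen gives an at least 56-fold lower number from compound 2 to compound 4 (1.74 log units; beyond the scatter), a large step and the first in the series at this place. Among the compounds shown here, the only earlier step, an at least 2.6-fold higher number from compound 1 to compound 2 (0.42 log units; beyond the scatter), concerned a substituent on the aromatic ring and said nothing about the saturated chain. The true size of the new step stays unknown because compound 2 sits at a limit and only a floor on its number exists: the limit of > 50000 nM in this assay, at which 2 of the 4 values shown sit.

From the compounds shown here alone, compound 3, which carries a long saturated chain with an amino group on the core, gives > 50000 nM, a limit of the assay and not a number, and it differs from compound 4 in two places, so it remains open whether the heptyl step holds on a core with other substituents. Also open, going by these compounds, is how the number would respond to a butyl group or a longer chain at this place, to an amine or a carboxylic acid there, or to heptyl combined with the fluoro group of compound 1.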